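A few compounds are considered here, and "the series" means these few. Any claim that something is new, unique, unknown or untested is made for them only; others in the source may bear on it.

Working notes on the series.

Among the compounds with values here, compound 1 `C=CC(=O)Nc1cccc(Nc2ncnc(Nc3ccc(C(=O)N4CCCCC4)cc3)n2)c1` is the only member with a number in hand: in a functional assay on Ramos cells (Homo sapiens) for antiproliferative activity, read by CCK-8 assay, with a stated time of 24 h (on this read-out higher numbers stand for weaker inhibition and lower numbers for stronger inhibition), compound 1 gives 6140 nM. Compound 2 `C=CC(=O)Nc1cccc(Nc2ncnc(Nc3ccc(-c4ccc(OC)nc4)cc3)n2)c1` carries the same shared core and acrylamide but a 6-methoxypyridin-3-yl group on the distal phenyl; in this assay compound 2 gives "not determined" (no result reported), so compound 2 stands nowhere on the numbers shown and no step from compound 1 to compound 2 can be drawn. Compound 3 `C=CC(=O)Nc1cccc(Nc2ncnc(Nc3ccc(OCCOC)cc3)n2)c1` differs from compound 2 in one place: 2-methoxyethoxy in place of 6-methoxypyridin-3-yl on an aromatic carbon. With no number for compound 2, neither size nor direction of the step from compound 2 to compound 3 in this assay can be taken from any measured pair, and none beyond the scatter can be asserted or denied. Within the data shown here, the only anchor is compound 1, whose read-out of 6140 nM sits in the micromolar range for a close analogue of the same core. On that basis alone, compound 3 is expected to give about 5000 nM in this assay, estimated between 1000 nM and 25000 nM, with a fair chance that only a limit is reported.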

Compound 3, half-maximal inhibitory concentration: 181000 nM
For compound 3 the middle estimate is 36-fold (1.56 log units) below the measured one, and the stated range ends below it.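

In this assay the exchange of (piperidin-1-yl)carbonyl for 2-methoxyethoxy on this aromatic carbon gives a 29-fold higher number from compound 1 to compound 3 (1.47 log units; beyond the scatter) and the step lies beyond the scatter. The position is therefore not indifferent to what it carries: compound 1 alone fixed a single level, whereas this only measured pair shows that the read-out moves strongly with the group placed here. This holds for one pair only, and nothing at hand gives a reason for the size of the step.

As far as these compounds go, the steps involving compound 2 cannot be read, so it stays open whether the 6-methoxypyridin-3-yl group, the one aryl substituent of the three, sits nearer to compound 1 or to compound 3. Also open, from the compounds shown here alone, is whether the step follows the loss of the carbonyl, the loss of the piperidine ring or the entry of the ether chain, a question that a morpholin-4-ylcarbonyl group, a carboxylic acid, a 2-(dimethylamino)ethoxy group or a longer ether chain on the same carbon would help to separate.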